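Fluorine Removal on a Saturated Chain and Lipophilicity

A few compounds are considered here, and "the series" means these few. Any claim that something is new, unique, unknown or untested is made for them only; others in the source may bear on it.

Compound 1, `OCCC(F)CC(F)(F)F`, gives 0.84 in a physicochemical assay for lipophilicity, read by NMR; on this read-out higher numbers stand for higher lipophilicity and lower numbers for lower lipophilicity.
Compound 2, `OCCC(F)(F)CC(F)(F)F`, gives 1.12 in this assay.
Compound 3, `CCC(F)(F)CO`, gives 0.67 in this assay.

Three fluorinated alcohols have been measured so far. Compound 2 sits higher than compound 3 in this assay by a margin beyond the usual scatter, while the numbers for compound 3 and compound 1 lie within the scatter of each other, so no order is claimed between those two. The difference between the core of compound 2 and the core of compound 3 is not broken down here.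

One change is seen directly: hydrogen in place of fluoro on a saturated chain carbon bound to a fluorine atom and two saturated chain carbons. Going from compound 2 to compound 1 it made a number 0.28 log units lower from compound 2 to compound 1 (within the scatter).

Compound 4, `CCC(F)CO`, is not yet measured. Among the measured compounds shown here, it differs from compound 3 by hydrogen in place of fluoro on a saturated chain carbon bound to a fluorine atom and two saturated chain carbons, the same change as the one between compound 2 and compound 1, at a place described in the same words. On the single shown example, the step from compound 3 to compound 4 in this assay is expected to be a number 0.28 log units lower from compound 3 to compound 4 (within the scatter), because a number 0.28 log units lower from compound 2 to compound 1 (within the scatter) is the only size this change has shown, and it came from a pair with a different core. Compound 4 is therefore estimated at 0.39, with a plausible range from 0.1 to 0.7.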

Compound 4, partition coefficient: 0.26
The estimate for compound 4 lay 0.13 log units above the measured number; measured number inside the range.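

In this assay the replacement of fluoro by hydrogen, on a saturated chain carbon bound to a fluorine atom and two saturated chain carbons, gave a number 0.41 log units lower from compound 3 to compound 4 (beyond the scatter) and so produced a step beyond the usual scatter on the core of compound 3. On the core of compound 2 the same replacement gave a number 0.28 log units lower from compound 2 to compound 1 (within the scatter), so the two pairs point the same way on paper, but only one of them clears the scatter, and they show neither a fixed size for this change nor that it can be carried reliably from one core to another. Nothing shown here accounts for the size of the step on either core.

Among the compounds shown here, with only two pairs, both of them fluorinated alcohols on saturated chains, the series leaves open how the same replacement would read on any further core, such as a longer chain. It also leaves open whether the step would hold if an amine or a carboxylic acid stood in place of the alcohol.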